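Changing the aryl group on the ring nitrogen of the piperazine amide

The compounds below may be only part of what the source reports. "The series", "measured", "known", "first", "only" and "open" are said of these compounds alone.

Measured so far:
compound 1 `CCC(C(=O)N1CCN(c2cccc(OC)c2)CC1)N1C(=O)CCC1=O` gives 25%
compound 2 `CCC(C(=O)N1CCN(c2ccccc2F)CC1)N1C(=O)CCC1=O` gives 100%

Among the compounds with values here, in a functional assay on the whole organism (strain Swiss) with Mus musculus as the target, in the maximal electroshock model, with a stated time of 0.25 h, at a dose of 300 mg/kg by the intraperitoneal route (a higher number here means a stronger effect of the compound at the dose given, a lower number a weaker effect), compound 2 stands highest of the two numbers; the only measured neighbour is compound 1, and the single step, a number 75 percentage points higher from compound 1 to compound 2 (beyond the scatter), is large. Compound 3 `CCC(C(=O)N1CCN(c2cccc(C)c2)CC1)N1C(=O)CCC1=O` has not been measured; it differs from compound 2 in one place: 3-methylphenyl in place of 2-fluorophenyl on an amine nitrogen in a ring. The step from compound 1 to compound 2 is the only one that bears on this, and it shows that the aryl group on the amine nitrogen in a ring can move the read-out a long way. Compound 3 carries a substituted phenyl of the kind seen in compound 1 rather than the 2-fluorophenyl of compound 2, so a drop is expected, of about a number 50 percentage points lower from compound 2 to compound 3 (beyond the scatter), though the uncertainty is wide. Compound 3 is therefore estimated at 50%, with a range from 15% to 100%.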

Compound 3, a percentage reported as activity, at one dose (the size of the read-out at that dose, not a potency): 100%
Estimate against measurement, compound 3: 50 percentage points below; low and high end bracket the measured number.
By their numbers in this assay, from the lowest: compound 1; then compounds 2 and 3 (each within the scatter of the next).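

In this assay the swap of 2-fluorophenyl for 3-methylphenyl gives no change at the digits printed from compound 2 to compound 3 (within the scatter) and so shows that a fluorine on this aryl group is not needed for the read-out of compound 2 to be reached. The change of methyl in place of methoxy on an aromatic carbon gives a number 75 percentage points higher from compound 1 to compound 3 (beyond the scatter) and so ties the low read-out of compound 1 to the methoxy group itself, not to the presence of a substituent on that ring carbon. Nothing available explains why these two groups differ so widely. Compounds 2 and 3 give the same number at a single dose, so any difference in potency between them remains hidden. On these data alone, it also remains open how the read-out would respond to an amine, a hydroxy group or a carboxylic acid on the phenyl ring, or to an unsubstituted phenyl.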